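The source may hold more compounds than are shown below. What is called first, only, known or untested is meant among the compounds shown, and "the series" means these compounds.

Measured so far in a functional assay on SK-MEL cells (Homo sapiens) for cytotoxicity, read by MTT assay, with a stated time of 6 days; a higher number here means that more compound is needed for the effect, a lower number that less compound is needed:
Compound 1 `COC(=O)c1c(-c2ccc(Br)cc2)oc2ccccc2c1=O`: > 25 ug/mL, a limit
Compound 2 `COC(=O)c1c(-c2ccc(N)cc2)oc2ccccc2c1=O`: > 25 ug/mL, a limit

Compound 2 has no numerical value, and its standing in this assay is known only as the limit > 25 ug/mL. The same holds across the series, with the limit of > 25 ug/mL in this assay, at which 2 of the 2 values shown sit.

Compound 3 `COC(=O)c1c(-c2ccc(OCc3ccccc3)cc2)oc2ccccc2c1=O` carries benzyloxy in place of amino on an aromatic carbon, para to a large group: benzyloxy in place of amino on an aromatic carbon.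

Among the compounds with values here, the only measured change, amino in place of bromo, is a step that the two limits leave unreadable from compound 1 to compound 2. It therefore supplies neither a size nor a direction for the new change. With no readable step to carry over, no step beyond the scatter is expected in this assay, and a further limit is the likeliest report. The expected change is a number no higher from compound 2 to compound 3 (the limit leaves the size open), though this estimate is weakly grounded. Compound 3 is estimated at 25 ug/mL, with an expected range of 12 ug/mL to 35 ug/mL.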

Compound 3, concentration for half-maximal effect: > 25 ug/mL
Compound 3 was reported as a limit; the forecaster's own chance of this, stated with the estimate: 75%; the middle value sits exactly at the limit.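

Compound 3 is a limit in this assay at > 25 ug/mL and gives no number. Within the data shown here, no step from compound 1 or compound 2 to compound 3 can be read. The compounds shown leave open whether any of these groups changes the concentration needed, and by how much.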